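Phenyl for chloro at the benzyl end of a thiourea

The compounds below may be only part of what the source reports. "The series", "measured", "known", "first", "only" and "open" are said of these compounds alone.

Two thioureas have been measured in an assay for inhibition of transient receptor potential cation channel subfamily V member 1 (Rattus norvegicus), with a stated time of 10 min; on this read-out higher numbers stand for weaker inhibition and lower numbers for stronger inhibition. Compound 1 `CC(C)(C)c1ccc(CCC/N=C(\S)NCc2ccc(NS(C)(=O)=O)c(F)c2)cc1` gives 2000 nM. Compound 2 `CS(=O)(=O)Nc1ccc(C/N=C(\S)NCc2ccc(Cl)cc2)cc1F` gives 340 nM, the lower of the two numbers, and the gap to compound 1 lies beyond the scatter. Compound 3 `CS(=O)(=O)Nc1ccc(C/N=C(\S)NCc2ccc(-c3ccccc3)cc2)cc1F` differs from compound 2 in one place: phenyl in place of chloro on an aromatic carbon, para to a large group. Within the data shown here, no measured pair shows such a change here, so the author expects only a modest step in this assay, more likely toward a somewhat higher number than a lower one, and possibly within the scatter. Compound 3 is expected to give 550 nM, in a range from 150 nM to 2000 nM. The expected step is a 1.6-fold higher number from compound 2 to compound 3 (0.21 log units; within the scatter).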

Compound 3, half-maximal inhibitory concentration: > 30000 nM
Compound 3 ended at the assay's limit (the forecaster's own chance of this, stated with the estimate: 5%); middle value at least 54-fold (1.73 log units) away from the limit.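

At this position, on an aromatic carbon para to a large group, the change from chloro to phenyl is far from neutral: it gives an at least 88-fold higher number from compound 2 to compound 3 (1.94 log units; beyond the scatter) in this assay. Among these compounds, the earlier compounds held no such pair, so this is the first sign that the position responds strongly to what sits there. Compound 3 stands at a limit of the assay, not at a number, so the true size of the step stays unknown: the limit of > 30000 nM in this assay, at which 1 of the 3 values shown sits.

The compounds shown leave open how a group such as methyl, methoxy or an amine would fare at this place, and whether any of them would stay near compound 2.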